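The source may report more compounds than this note shows. Statements on the series, on what has been measured and on what is new or still open speak of the compounds shown alone.

Compound 1 `Oc1ccccc1-c1cc(-c2cccc(F)c2)cc(-c2ccccc2O)n1` and compound 2 `Oc1ccccc1-c1cc(-c2ccc(F)cc2)cc(-c2ccccc2O)n1` share a core that carries two 2-hydroxyphenyl groups; compound 3 `Oc1cccc(-c2cc(-c3cccc(F)c3)cc(-c3cccc(O)c3)n2)c1` carries two 3-hydroxyphenyl groups instead. In a functional assay on HeLa cells (Homo sapiens) for inhibition (a lower number here means a stronger inhibitor, a higher number a weaker inhibitor), compound 1 gives only a limit, > 50000 nM. Compound 2 likewise reaches only a limit in this assay, > 50000 nM. The step that the two limits leave unreadable from compound 1 to compound 2, that is 4-fluorophenyl in place of 3-fluorophenyl on an aromatic carbon, cannot be sized because of the limit of > 50000 nM in this assay, at which 2 of the 3 values shown sit. Compound 3 gives 1400 nM in this assay. The difference between the core of compound 1 and the core of compound 3 is not broken down here. Compound 4 `Oc1cccc(-c2cc(-c3ccc(F)cc3)cc(-c3cccc(O)c3)n2)c1` is not yet measured; it differs from compound 3 by 4-fluorophenyl in place of 3-fluorophenyl on an aromatic carbon, the same kind of change as from compound 1 to compound 2, but the place is meta to two 3-hydroxyphenyl groups rather than two 2-hydroxyphenyl groups. With the earlier step unreadable, the expected step of no change at the digits printed from compound 3 to compound 4 (within the scatter) rests only on compound 3 with 1400 nM. Compound 4 is therefore expected near 1400 nM, between 500 nM and 4000 nM.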

Compound 4, half-maximal inhibitory concentration: 1280 nM
For compound 4 the middle estimate is 1.1-fold (0.04 log units) above the measured one; the measured number falls inside the stated range.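

With two 3-hydroxyphenyl groups on the shared core, 4-fluorophenyl in place of 3-fluorophenyl gives a 1.1-fold lower number from compound 3 to compound 4 (0.04 log units; within the scatter) in this assay. The same change on the core with two 2-hydroxyphenyl groups cannot be read, because compound 1 and compound 2 both give only a limit: the limit of > 50000 nM in this assay, at which 2 of the 4 values shown sit. The step is therefore readable on one core only, and these data do not show whether it carries over from one core to the other.

Going by these compounds, it remains open what an amine or a carboxylic acid in place of the hydroxyl on the two 3-hydroxyphenyl groups would give in this assay. Also open, on these data alone, is what a nitrile in place of the fluorine on the 4-fluorophenyl group would give.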